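Isopropyl for Cyclohexyl, Tried Again on a Second Core

The source may hold more compounds than are shown below. What is called first, only, known or untested is meant among the compounds shown, and "the series" means these compounds.

Measured so far in an assay on isolated protein with Bile acid receptor (Homo sapiens) as the target; a lower number here means that less compound is needed, a higher number that more compound is needed for the effect:
compound 1 `COC(=O)/C=C/c1cccc(N(Cc2ccc(-c3c(OC)cccc3OC)cc2)C(=O)C2CCCCC2)c1`: 77 nM
compound 2 `COC(=O)/C=C/c1cccc(N(Cc2ccc(-c3c(OC)cccc3OC)cc2)C(=O)C(C)C)c1`: 95 nM
compound 3 `COC(=O)/C=C/c1cccc(N(Cc2ccc(/C=C/c3cccc(Cl)c3)cc2)C(=O)C2CCCCC2)c1`: 165 nM

Compound 1 and compound 2 share one core and differ only by isopropyl in place of cyclohexyl on a carbonyl carbon. That exchange gave a 1.2-fold higher number from compound 1 to compound 2 (0.09 log units; within the scatter), so the two numbers cannot be told apart. Compound 3 carries a different core; the difference from compound 1 is 2-(3-chlorophenyl)ethenyl in place of 2,6-dimethoxyphenyl on an aromatic carbon, and this gave a 2.1-fold higher number from compound 1 to compound 3 (0.33 log units; beyond the scatter).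

Compound 4 `COC(=O)/C=C/c1cccc(N(Cc2ccc(/C=C/c3cccc(Cl)c3)cc2)C(=O)C(C)C)c1` has not been measured. It stands to compound 3 as compound 2 stands to compound 1: the difference is isopropyl in place of cyclohexyl on a carbonyl carbon, and the surroundings of the changed carbonyl carbon read the same in both pairs, so this is the same change carried onto the second core. On the first core the change barely moved the number; on the new core the expected step is a 1.2-fold higher number from compound 3 to compound 4 (0.08 log units; within the scatter), resting on that earlier result, a 1.2-fold higher number from compound 1 to compound 2 (0.09 log units; within the scatter), and on compound 3 at 165 nM. Compound 4 is therefore estimated at 200 nM, with a plausible range from 100 nM to 400 nM.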

Compound 4, half-maximal effective concentration: 164 nM
Beside the measured number, compound 4's estimate is 1.2-fold (0.09 log units) above it; the measured number falls inside the stated range.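

In this assay, isopropyl in place of cyclohexyl on the carbonyl carbon again left the number unmoved on the second core, with a 1.0-fold lower number from compound 3 to compound 4 (0.00 log units; within the scatter), and the two cores agree on this exchange: the same change on two cores in this assay, a 1.2-fold higher number (0.09 log units; within the scatter) from compound 1 to compound 2 and a 1.0-fold lower number (0.00 log units; within the scatter) from compound 3 to compound 4, 1.2-fold (0.09 log units) apart, within the scatter of two such steps. The other exchange, 2-(3-chlorophenyl)ethenyl in place of 2,6-dimethoxyphenyl, also reads alike with either carbonyl substituent, with a 1.7-fold higher number from compound 2 to compound 4 (0.24 log units; within the scatter), and the two steps do not differ: the same change on two cores in this assay, a 2.1-fold higher number (0.33 log units; beyond the scatter) from compound 1 to compound 3 and a 1.7-fold higher number (0.24 log units; within the scatter) from compound 2 to compound 4, 1.2-fold (0.09 log units) apart, within the scatter of two such steps. Across these four compounds, then, each change gives much the same step whichever form of the other position it is made on, but this does not show that the same would hold on any further core, and it does not explain why the number stays put.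

Going by these compounds, it remains open whether a carbonyl substituent of another kind, such as a methyl, a phenyl or a chain ending in an amine, would also leave the number in place on both cores. On these data alone, it is equally open whether a carboxylic acid in place of the methyl ester would carry from one core to the other in the same way.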